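This account rests on a few compounds, and the source may have more. Where it says the series, first, only, none or still open, it means among the compounds named here.

In an ADME assay on microsomes from liver (Mus musculus) for metabolic stability, read by LC-MS, with NADPH named in the record, with a stated time of 60 min, tested at 1 uM, in the absence of a further agent (a higher number here means that more of the compound is left, a lower number that less of the compound is left), compound 1 `COc1ccc(-c2scc3c(N4CC[C@@H](NC(C)=O)C4)nc(C)nc23)cc1OC` gives > 95% as its reading, which is a limit and not a number. Compound 2 `COc1ccc(-c2c(C)nc3c(N4CC[C@@H](NC(C)=O)C4)cc(C)nn23)cc1F` gives > 95% as its reading, again only a limit. Compound 2 therefore has no exact number of its own and shares one mark with compound 1 (the limit of > 95% in this assay, at which 2 of the 2 values shown sit). Compound 3 `CC(=O)N[C@@H]1CCN(c2cc(C)nn3c(-c4ccc5cc[nH]c5c4)c(C)nc23)C1` differs from compound 2 at one place, an aromatic carbon of a five-membered aromatic ring with 2 nitrogen, where 1H-indol-6-yl stands in place of 3-fluoro-4-methoxyphenyl (1H-indol-6-yl in place of 3-fluoro-4-methoxyphenyl on an aromatic carbon). For the measured compounds named here, no measured step bears on this change, and with both values at the limit the data show no trend. A modest fall in this assay is expected, and the estimated step of a number at least 13 percentage points lower from compound 2 to compound 3 (beyond the scatter) may not go beyond the scatter. Compound 3 is estimated at 82% of the compound left (expected range 55% to 98%).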

Compound 3, percent of the compound remaining: > 95%
Compound 3 ended at the assay's limit (the forecaster's own chance of this, stated with the estimate: 25%); at least 13 percentage points between middle value and limit.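

No step can be read from compound 2 to compound 3 in this assay, since both readings are limits and not numbers: the limit of > 95% in this assay, at which 3 of the 3 values shown sit.

The compounds shown leave open whether 1H-indol-6-yl in place of 3-fluoro-4-methoxyphenyl changes the percent of the compound remaining at all, and how compound 1, compound 2 and compound 3 would rank in this assay.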